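Returning to a trifluoromethyl-bearing aryl group

The source may hold more compounds than are shown below. What is called first, only, known or untested is meant among the compounds shown, and "the series" means these compounds.

Of the compounds shown here, three sharing one core have been measured in a functional assay on MCF7 cells (Homo sapiens) for inhibition; on this read-out higher numbers stand for weaker inhibition and lower numbers for stronger inhibition. Compound 1 `CC/C(=C(/c1ccc(/C=C/C(=O)O)cc1)c1cc2ccccc2[nH]1)c1ccccc1C(F)(F)F` gives 8 nM and compound 2 `CC/C(=C(/c1ccc(/C=C/C(=O)O)cc1)c1cc2ccccc2[nH]1)c1ccc(C#N)cc1` gives 278 nM. Compound 3 `CC/C(=C(/c1ccc(/C=C/C(=O)O)cc1)c1cc2ccccc2[nH]1)c1cccc(F)c1C#N` gives 40 nM, the second highest of the three, standing nearer to compound 1 than to compound 2. Compound 4 `CC/C(=C(/c1ccc(/C=C/C(=O)O)cc1)c1cc2ccccc2[nH]1)c1ccc(Cl)cc1C(F)(F)F` is not yet measured; it differs from compound 3 by 4-chloro-2-(trifluoromethyl)phenyl in place of 2-cyano-3-fluorophenyl on a double-bonded chain carbon bound to a double-bonded chain carbon and a saturated chain carbon. Going by the values given here, the step that bears on this is a 5.0-fold higher number from compound 1 to compound 3 (0.70 log units; beyond the scatter): compound 4 returns to the 2-(trifluoromethyl)phenyl of compound 1, now as 4-chloro-2-(trifluoromethyl)phenyl, and no measured step speaks to the added chlorine. Reversing that step is expected to give a 3.3-fold lower number from compound 3 to compound 4 (0.52 log units; beyond the scatter). Compound 4 is therefore estimated at 12 nM, within 4 nM to 40 nM.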

Compound 4, half-maximal inhibitory concentration: 4 nM
The estimate for compound 4 lay 3.0-fold (0.48 log units) above the measured number; the measured number falls inside the stated range.
By their numbers in this assay, from the lowest: compounds 4 and 1 (each within the scatter of the next); then compound 3; then compound 2.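

In this assay the change to 4-chloro-2-(trifluoromethyl)phenyl gives a 10-fold lower number from compound 3 to compound 4 (1.00 log units; beyond the scatter) and a 70-fold lower number from compound 2 to compound 4 (1.84 log units; beyond the scatter) at this double-bonded chain carbon. Chloro in place of hydrogen on an aromatic carbon gives a 2.0-fold lower number from compound 1 to compound 4 (0.30 log units; within the scatter) and so shows that the 2-(trifluoromethyl)phenyl of compound 1 can carry this added atom without a change that stands out from the scatter. No measured evidence explains these differences. The compounds shown leave open whether a methoxy group or an amine in the place of the chloro would keep the number as low, and whether a bromine would do the same.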